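The compounds below may be only part of what the source reports. "The series", "measured", "known", "first", "only" and "open" are said of these compounds alone.

Measured so far:
compound 1 `COc1cc(-c2nnc3n2NC(c2ccco2)C(C(=O)c2ccccc2F)S3)cc(OC)c1OC` — 78700 nM
compound 2 `COc1cc(-c2nnc3n2NC(c2ccco2)C(C(=O)c2ccc(O)cc2)S3)cc(OC)c1OC` — 93400 nM

In a functional assay on A549 cells (Homo sapiens) for cytotoxicity, read by MTT assay, with a stated time of 48 h (on this read-out higher numbers stand for weaker inhibition and lower numbers for stronger inhibition), compound 2 gives 93400 nM, which is the higher of the two numbers recorded, but the step of a 1.2-fold higher number from compound 1 to compound 2 (0.07 log units; within the scatter) is within the scatter, so compound 1 and compound 2 are not separable on this read-out. Compound 3 `COc1cc(-c2nnc3n2NC(c2ccco2)C(C(=O)c2ccc(-c4ccccc4)cc2)S3)cc(OC)c1OC` is the next compound and differs from compound 2 by phenyl in place of hydroxy on an aromatic carbon. For the measured compounds named here, the only step measured, a 1.2-fold higher number from compound 1 to compound 2 (0.07 log units; within the scatter), exchanges one aryl group on the carbonyl for another and does not reach beyond the scatter; no step removes a hydroxy or introduces a phenyl, so the change to compound 3 is not directly covered. On that basis the expected step of a 1.2-fold lower number from compound 2 to compound 3 (0.07 log units; within the scatter) carries no clear direction beyond the scatter. Compound 3 is therefore expected to give about 80000 nM in this assay, with a range of 30000 nM to 200000 nM.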

Compound 3, half-maximal inhibitory concentration: > 100000 nM
Compound 3: only a limit was reported; the forecaster's own chance of this, stated with the estimate: 20%; middle value at least 1.2-fold (0.09 log units) from the limit.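

In this assay the result for compound 3 is a limit and not a number: the limit of > 100000 nM in this assay, at which 1 of the 3 values shown sits.

Phenyl in place of hydroxy at this position, para to a large group, gives an at least 1.0-fold higher number from compound 2 to compound 3 (0.02 log units; that floor lies within the scatter), and 4-phenylphenyl in place of 2-fluorophenyl on the carbonyl carbon gives an at least 1.2-fold higher number from compound 1 to compound 3 (0.10 log units; that floor lies within the scatter); neither floor clears the scatter, so no order among the three compounds can be read. What this adds is that a second aromatic ring at this place brings no stronger inhibition, so this aryl position has not yet yielded a step towards lower numbers.

On these data alone, whether an amine or a carboxylic acid at the same place would move the number beyond the scatter stays open. As far as these compounds go, the rest of the shared core is constant across all three compounds, so its part in the activity also stays open.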